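The source may report more compounds than this note shows. Statements on the series, on what has been measured and on what is new or still open speak of the compounds shown alone.

Series notes. Compound 1 `CC(O)(CS(=O)(=O)c1ccc(F)cc1)C(=O)Nc1ccc(S(F)(F)(F)(F)F)cc1` and compound 2 `CC(O)(CS(=O)(=O)c1cccc(C(F)(F)F)c1)C(=O)Nc1ccc(S(F)(F)(F)(F)F)cc1` share one core; compound 3 `CC(O)(CS(=O)(=O)c1ccc(F)cc1)C(=O)Nc1cccc(S(F)(F)(F)(F)F)c1` and compound 4 `CC(O)(CS(=O)(=O)c1cccc(C(F)(F)F)c1)C(=O)Nc1cccc(S(F)(F)(F)(F)F)c1` share another. The difference between the two cores is not broken down here; compound 1 and compound 3 have the same atoms, joined differently.

In a functional assay on LNCaP cells (Homo sapiens) for antiproliferative activity, read by propidium iodide staining, with a stated time of 96 h (a higher number here means a weaker inhibitor, a lower number a stronger inhibitor), compound 1 gives 18200 nM and compound 2 gives 21000 nM. The change between them, (3-(trifluoromethyl)phenyl in place of 4-fluorophenyl on a sulfonyl sulfur), made a step of a 1.2-fold higher number from compound 1 to compound 2 (0.06 log units; within the scatter). In this assay compound 3 gives 32600 nM; its value and those of compound 1 and compound 2 lie within the scatter of one another, so no ordering among the three is drawn.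

Compound 4 carries the same change on the core of compound 3: 3-(trifluoromethyl)phenyl in place of 4-fluorophenyl on a sulfonyl sulfur. Both occurrences of this change sit at a place described in the same words, so it is taken as the same change. Among the measured compounds shown here, because the step of a 1.2-fold higher number from compound 1 to compound 2 (0.06 log units; within the scatter) was within the scatter, the step from compound 3 to compound 4 is expected to be of a similar size, a 1.2-fold higher number from compound 3 to compound 4 (0.07 log units; within the scatter), with wide uncertainty since only one prior example exists. In this assay compound 4 is therefore estimated at 38000 nM, with a likely range from 19000 nM to 76000 nM.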

Compound 4, half-maximal inhibitory concentration: 21800 nM
Compound 4: the middle estimate sits 1.7-fold (0.24 log units) above what was measured, within the range that was stated.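

In this assay the new step is a 1.5-fold lower number from compound 3 to compound 4 (0.17 log units; within the scatter). Set beside the earlier step on the core of compound 1, it shows no difference between the two cores that the measurements can separate: the same change on two cores in this assay, a 1.2-fold higher number (0.06 log units; within the scatter) from compound 1 to compound 2 and a 1.5-fold lower number (0.17 log units; within the scatter) from compound 3 to compound 4, 1.7-fold (0.24 log units) apart, within the scatter of two such steps Replacing 4-fluorophenyl with 3-(trifluoromethyl)phenyl on a sulfonyl sulfur therefore gave no step beyond the scatter on either core, but this does not show that the change has a common size or direction, and two pairs within the scatter do not establish that it would behave the same way on any further core.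

The compounds shown hold only these two groups on the sulfonyl sulfur, so they leave open whether a different group there, such as a phenyl ring carrying an amine or a carboxylic acid, would give a step beyond the scatter. They also leave open whether any such step would carry from one core to the other.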